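Dimethylamino in Place of Methoxy on the Aryl Ring

The source may report more compounds than this note shows. Statements on the series, on what has been measured and on what is new or still open speak of the compounds shown alone.

Among the compounds with values here, compound 3 `COc1ccc(/C=C2\CCN=C2c2cccnc2)cc1` is one of three compounds so far measured in an assay for displacement of a labelled ligand from Nicotinic acetylcholine receptor alpha8 subunit (Periplaneta americana), read by scintillation counting, with a stated time of 2 h, at 24 degrees C; a lower number here means a stronger inhibitor, a higher number a weaker inhibitor. In this assay compound 3 gives > 10000 nM, which is a limit of the assay and not a number. Compound 1 `C(=C1\CCN=C1c1cccnc1)\c1ccccc1` also gives only a limit in this assay, > 10000 nM. Compound 2 `COc1ccc(/C=C2\CCN=C2c2cccnc2)c(OC)c1`, which carries two methoxy groups, gives 4550 nM in this assay. The step of an at least 2.1-fold higher number from compound 2 to compound 3 (0.34 log units; beyond the scatter) shows that loss of one methoxy group costs at least a modest amount of binding, whereas the step that the two limits leave unreadable from compound 1 to compound 3 cannot be read because of the limit of > 10000 nM in this assay, at which 2 of the 3 values shown sit.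

Compound 4 `CN(C)c1ccc(/C=C2\CCN=C2c2cccnc2)cc1` differs from compound 3 by dimethylamino in place of methoxy on an aromatic carbon. Within the data shown here, no measured pair exchanges a methoxy for a dimethylamino, so only the position of compound 3 at the limit and the modest step from compound 2 bear on this change. Compound 4 is therefore expected to stay close to where compound 3 stands, the expected step being a step that the limit leaves unreadable from compound 3 to compound 4. The estimate for compound 4 in this assay is 12000 nM, within 2500 nM to 60000 nM.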

Compound 4, half-maximal inhibitory concentration: 5490 nM
Compound 4: middle estimate off by 2.2-fold (0.34 log units), on the high side; the range from low to high includes it.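

Compound 4 shows that dimethylamino, on an aromatic carbon para to a large group, can bring a value inside the range of the assay, where methoxy and hydrogen at that place left only a limit. Against methoxy the change reads as an at least 1.8-fold lower number from compound 3 to compound 4 (0.26 log units; that floor lies within the scatter) and against hydrogen as an at least 1.8-fold lower number from compound 1 to compound 4 (0.26 log units; that floor lies within the scatter). As far as these compounds go, neither floor goes beyond the scatter, and the true size of both steps stays unknown, as each rests on a limit: the limit of > 10000 nM in this assay, at which 2 of the 4 values shown sit.

The compounds shown leave open whether a plain amino group or a hydroxyl at this place would also give a readable value in this assay. They also leave open whether a second group on the aromatic ring, such as the second methoxy of compound 2, would change the result with dimethylamino in place.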